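Swapping the aryl group on a shared core

The compounds below may be only part of what the source reports. "The series", "measured", "known", "first", "only" and "open" are said of these compounds alone.

Values in a physicochemical assay for lipophilicity, measured as octanol-water partition, at pH 7.4; on this read-out lower numbers stand for lower lipophilicity and higher numbers for higher lipophilicity:
- Compound 1 `Cc1oc(-c2ccc(Cl)cc2)nc1C(=O)N[C@H]1CN(S(=O)(=O)c2ccccc2)C[C@@H]1C(=O)N[C@H]1CCCNC1`: 2
- Compound 2 `Cc1oc(-c2ccc(C(F)(F)F)cc2)nc1C(=O)N[C@H]1CN(S(=O)(=O)c2ccccc2)C[C@@H]1C(=O)N[C@H]1CCCNC1`: 2.3

In this assay, going by the values given here, compound 2 stands at 2.3, and the only other measured compound, compound 1, lies within the scatter of it. The next compound, compound 3 `Cc1oc(-c2ccccc2Cl)nc1C(=O)N[C@H]1CN(S(=O)(=O)c2ccccc2)C[C@@H]1C(=O)N[C@H]1CCCNC1`, has not yet been measured. It carries 2-chlorophenyl in place of 4-(trifluoromethyl)phenyl on an aromatic carbon of a five-membered aromatic ring with 1 nitrogen and 1 oxygen (2-chlorophenyl in place of 4-(trifluoromethyl)phenyl on an aromatic carbon).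

Among the compounds with values here, one measured step bears on this change: a number 0.30 log units higher from compound 1 to compound 2 (within the scatter). That step, trifluoromethyl in place of chloro on an aromatic carbon, stays within the scatter, so swapping these two groups has not yet produced a clear shift. Within the data shown here, no measured compound carries 2-chlorophenyl, which leaves the new placement of the chloro untested. The closest guide is therefore compound 1 at 2, which also carries chloro. A modest move towards lower numbers is expected, and the estimated step is a number 0.40 log units lower from compound 2 to compound 3 (beyond the scatter). For compound 3 the expected value is 1.9, with an estimated range from 1.5 to 2.3.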

Compound 3, distribution coefficient: 1.6
Compound 3: middle estimate off by 0.30 log units, on the high side, within the range that was stated.
By their numbers in this assay, from the lowest: compound 3; then compounds 1 and 2 (each within the scatter of the next).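

In this assay, the aryl group on the shared core now produces a step beyond the scatter, which the exchange of chloro and trifluoromethyl alone did not: 2-chlorophenyl in place of 4-(trifluoromethyl)phenyl gives a number 0.70 log units lower from compound 2 to compound 3 (beyond the scatter) on this read-out. The comparison with 4-chlorophenyl is the more telling one, since the phenyl ring and its chloro are kept and only the placement of the chloro differs, and it gives a number 0.40 log units lower from compound 1 to compound 3 (beyond the scatter) as a modest step, so for these compounds the placement of the chloro counts for more than the choice between the two groups compared earlier. Why the number moves with this placement cannot be said, as no measurement on these compounds addresses the cause.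

As far as these compounds go, it remains open whether trifluoromethyl, placed where 2-chlorophenyl carries its chloro, would give a step of similar size, so these three compounds cannot separate placement from group in general. Also open, from the compounds shown here alone, is how this position would respond to a phenyl ring bearing an amine or a carboxylic acid, or to a longer chain in place of the aryl group.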